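Replacing 4-methoxyphenyl with 2-(pyrrolidin-1-yl)ethyl on the amide

The source may hold more compounds than are shown below. What is called first, only, known or untested is meant among the compounds shown, and "the series" means these compounds.

In a functional assay on A549 cells (Homo sapiens) for inhibition, read by MTT assay, with a stated time of 72 h (a higher number here means a weaker inhibitor, a lower number a stronger inhibitor), compound 1 `O=C(CCC(=O)OCCCCCCSc1ccc([N+](=O)[O-])c2nonc12)Nc1ccccc1` gives 1960 nM, compound 2 `Cc1ccccc1NC(=O)CCC(=O)OCCCCCCSc1ccc([N+](=O)[O-])c2nonc12` gives 4200 nM, and compound 3 `COc1ccc(NC(=O)CCC(=O)OCCCCCCSc2ccc([N+](=O)[O-])c3nonc23)cc1` gives 6480 nM. Compound 3 cannot be told apart from compound 2, with a 1.5-fold higher number from compound 2 to compound 3 (0.19 log units; within the scatter), but it stands clearly apart from compound 1, with a 3.3-fold higher number from compound 1 to compound 3 (0.52 log units; beyond the scatter). Compound 4 `O=C(CCC(=O)OCCCCCCSc1ccc([N+](=O)[O-])c2nonc12)NCCN1CCCC1` changes the group on the amide-type nitrogen: 2-(pyrrolidin-1-yl)ethyl in place of 4-methoxyphenyl on an amide-type nitrogen. Adding a methyl to the ring gave a 2.1-fold higher number from compound 1 to compound 2 (0.33 log units; beyond the scatter), but no measured step removes the aromatic ring, so these steps guide the size only loosely. A modest move toward a lower number is expected, as a 1.6-fold lower number from compound 3 to compound 4 (0.21 log units; within the scatter). Compound 4 is estimated at 4000 nM, with an expected range of 1300 nM to 12500 nM.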

Compound 4, half-maximal inhibitory concentration: 3240 nM
Beside the measured number, compound 4's estimate is 1.2-fold (0.09 log units) above it, and the stated range covers the measured number.
By their numbers in this assay, from the lowest: compounds 1, 4, 2 and 3 (each within the scatter of the next, the first and the last beyond it).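

In this assay, this place on the amide-type nitrogen accepts a group with no aromatic ring: the steps are a 2.0-fold lower number from compound 3 to compound 4 (0.30 log units; within the scatter), a 1.3-fold lower number from compound 2 to compound 4 (0.11 log units; within the scatter) and a 1.7-fold higher number from compound 1 to compound 4 (0.22 log units; within the scatter). All three lie within the scatter, so 2-(pyrrolidin-1-yl)ethyl cannot be told apart here from phenyl, 2-methylphenyl or 4-methoxyphenyl. Nothing shown gives a reason for this result. As far as these compounds go, it remains open whether a simpler amine, such as 2-(dimethylamino)ethyl, or a carboxylic acid would fit here as well. From the compounds shown here alone, it is also open whether a longer chain in place of the ethyl would shift the number.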